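Extending the dimethylamino chain: compound 3 to compound 4

The source may hold more compounds than are shown below. What is called first, only, known or untested is meant among the compounds shown, and "the series" means these compounds.

Measured in a functional assay on HL-60 cells (Homo sapiens) for antiproliferative activity, read by MTT assay, with a stated time of 48 h; a higher number here means a weaker inhibitor, a lower number a stronger inhibitor:
Compound 1 `Cn1c(N)c(-c2nc3ccccc3[nH]2)c2nc(C#N)c(C#N)nc21` gives > 50000 nM, which is a limit of the assay.
Compound 2 `CCCn1c(N)c(-c2nc3ccccc3[nH]2)c2nc(C#N)c(C#N)nc21` gives 45200 nM.
Compound 3 `CN(C)CCCn1c(N)c(-c2nc3ccccc3[nH]2)c2nc(C#N)c(C#N)nc21` gives 870 nM.
Compound 4 `CN(C)CCCCCn1c(N)c(-c2nc3ccccc3[nH]2)c2nc(C#N)c(C#N)nc21` is still unmeasured.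

The lowest number in this assay belongs to compound 3. The nearest measured number marks a 52-fold lower number from compound 2 to compound 3 (1.72 log units; beyond the scatter).

The next change is 2-(dimethylamino)ethyl in place of dimethylamino on a saturated chain carbon, three bonds along the chain from an aromatic nitrogen. The side chain thus goes from 3-(dimethylamino)propyl to 5-(dimethylamino)pentyl, and the dimethylamino group stays.

Within the data shown here, three measured steps bear on this. Two are large: a 52-fold lower number from compound 2 to compound 3 (1.72 log units; beyond the scatter), and an at least 57-fold lower number from compound 1 to compound 3 (1.75 log units; beyond the scatter). The third, an at least 1.1-fold lower number from compound 1 to compound 2 (0.04 log units; that floor lies within the scatter), has a floor within the scatter. Both steps that start at compound 1 rest on (the limit of > 50000 nM in this assay, at which 1 of the 3 values shown sits). All the large steps involve gaining the dimethylamino group, which compound 4 keeps. Among the measured compounds shown here, no measured step lengthens the chain with that group in place, so the direction remains open and only a modest change is expected in this assay, with none beyond the scatter as the central case. The expected change is a 1.2-fold lower number from compound 3 to compound 4 (0.09 log units; within the scatter). For compound 4 the estimated value is 700 nM, with an expected range of 150 nM to 3500 nM.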

Compound 4, half-maximal inhibitory concentration: 3420 nM
The estimate for compound 4 lay 4.9-fold (0.69 log units) below the measured number, within the range that was stated.
By their numbers in this assay, from the lowest: compound 3; then compound 4; then compound 2. At a limit, above all of these: compound 1.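

In this assay, the length of the chain carrying the dimethylamino group now has a measured effect: going from 3-(dimethylamino)propyl to 5-(dimethylamino)pentyl gives a 3.9-fold higher number from compound 3 to compound 4 (0.59 log units; beyond the scatter). The longer chain keeps much of the gain over the plain alkyl chains, with a 13-fold lower number from compound 2 to compound 4 (1.12 log units; beyond the scatter) and an at least 14-fold lower number from compound 1 to compound 4 (1.16 log units; beyond the scatter), although the second of these steps is only a floor, since compound 1 sits at a limit of the assay: the limit of > 50000 nM in this assay, at which 1 of the 4 values shown sits. Adding the dimethylamino group therefore does not give a fixed gain in this short series, and the size of the step differs with the chain that carries it, with the same reservation for the step from compound 1: the same change on two cores in this assay, an at least 57-fold lower number (1.75 log units; beyond the scatter) from compound 1 to compound 3 and a 13-fold lower number (1.12 log units; beyond the scatter) from compound 2 to compound 4, at least 4.3-fold (0.63 log units) apart, beyond the scatter of two such steps.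

The compounds shown leave open whether the number changes steadily with chain length, since a 4-(dimethylamino)butyl or a 2-(dimethylamino)ethyl side chain on the shared core would test that directly. They also leave open whether a primary amine or a diethylamino group in place of dimethylamino on the 3-(dimethylamino)propyl chain would match compound 3.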